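The source may report more compounds than this note shows. Statements on the series, on what has been measured and on what is new or still open speak of the compounds shown alone.

Series notes. Compound 1 `CCN1CCc2c(sc(NC(=O)Nc3ccc(Cl)cc3)c2C#N)C1` is read in a functional assay (strain AB) with Danio rerio as the target, read by microscopy, with a stated time of 1 h; a higher number here means that more compound is needed for the effect, a lower number that less compound is needed. There compound 1 gives > 25000 nM, a limit of the assay rather than a number. Compound 2 `CCN1CCc2c(ccc(NC(=O)Nc3ccc(Cl)cc3)c2C(N)=O)C1` gives > 25000 nM, again a limit. Compound 3 `CCN1CCc2c(sc(NC(=O)C3(c4ccc(Cl)cc4)CC3)c2C(N)=O)C1` gives > 25000 nM, also a limit. Compound 1 thus stands at the limit of > 25000 nM in this assay, at which 3 of the 3 values shown sit, with no numbered value anywhere in the set. The step to compound 4 `CCN1CCc2c(sc(NC(=O)Nc3ccc(Cl)cc3)c2C(=O)OC)C1` is methoxycarbonyl in place of cyano on an aromatic carbon. With every measured value at the limit, no direction can be drawn from the shown data, and the change is expected to leave the reading at or near the limit, giving no step beyond the scatter. For compound 4 the estimated value in this assay is 40000 nM, within 10000 nM to 200000 nM. The expected step is a step that the limit leaves unreadable from compound 1 to compound 4.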

Compound 4, half-maximal effective concentration: > 25000 nM
Compound 4: a limit, no number; the forecaster's own chance of this, stated with the estimate: 80%; the middle value is on the limit's open side.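

Compound 1 and compound 4 both stand at a limit in this assay, so no step can be read between them. The compounds shown leave open which change to the shared core, if any, would give a numbered value in this assay.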